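Methyl on the shared core and cytotoxicity in MT4 cells

The compounds below may be only part of what the source reports. "The series", "measured", "known", "first", "only" and "open" are said of these compounds alone.

The series is followed in an ADME assay on MT4 cells (Homo sapiens) for cytotoxicity, read by MTT assay, with a stated time of 4 days; on this read-out higher numbers stand for lower toxicity in this test and lower numbers for higher toxicity in this test. Compound 1 `CC1CCN(c2nc(Cc3c(F)cccc3F)cc(=O)[nH]2)CC1` gives only a limit there, > 78000 nM. Compound 2 `Cc1c(Cc2c(F)cccc2F)nc(N2CCC(C)CC2)[nH]c1=O` likewise gives only a limit, > 75000 nM. The change between them is methyl in place of hydrogen on an aromatic carbon. The step that the two limits leave unreadable from compound 1 to compound 2 cannot be sized because the limit of > 78000 nM in this assay, at which 1 of the 3 values shown sits, and the limit of > 75000 nM in this assay, at which 1 of the 3 values shown sits, cap both values.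

Among the compounds with values here, compound 3 `CC(c1cc(=O)[nH]c(N(C)C)n1)c1c(F)cccc1F` is the one member with a number: in this assay compound 3 gives 89000 nM. The difference between the core of compound 3 and the core of compound 1 is not broken down here.

Compound 4 `Cc1c(C(C)c2c(F)cccc2F)nc(N(C)C)[nH]c1=O` is not yet measured. It differs from compound 3 by methyl in place of hydrogen on an aromatic carbon. This is the same kind of change as from compound 1 to compound 2, though the place differs: ortho to a large group and para to a dimethylamino group rather than ortho to a group of 9 heavy atoms and para to a 4-methylpiperidin-1-yl group. Since the measured pair offers no readable size, the step of a 1.0-fold higher number from compound 3 to compound 4 (0.00 log units; within the scatter) is expected to stay within the usual scatter of compound 3 at 89000 nM. Compound 4 is estimated at 90000 nM, between 45000 nM and 180000 nM, with a fair chance the assay again reports only a limit.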

Compound 4, half-maximal cytotoxic concentration: > 17000 nM
Compound 4 gave a limit, no number; the forecaster's own chance of this, stated with the estimate: 50%; the middle value is on the limit's open side.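

Compound 4 gives only a limit, > 17000 nM. Within the data shown here, no new step can therefore be read between compound 3 and compound 4, and the methyl change remains unsized in both pairs. The compounds shown leave open whether methyl in place of hydrogen on an aromatic carbon changes cytotoxicity in these cells on either core.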